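A few compounds are considered here, and "the series" means these few. Any claim that something is new, unique, unknown or untested is made for them only; others in the source may bear on it.

Working notes on the series. Within the data shown here, in a functional assay on A549 cells (Homo sapiens) for antiproliferative activity, with a stated time of 72 h (on this read-out lower numbers stand for stronger inhibition and higher numbers for weaker inhibition), compound 1 (`COc1cc(OC)c(C(=O)/C=C/c2ccccc2Cl)c(O)c1CN1CCCC1`) gives 2600 nM and compound 2 (`COc1cc(OC)c(C(=O)/C=C/c2ccccc2Cl)c(O)c1CN(C)CC(=O)O`) gives 79400 nM, the higher of the two numbers measured so far. Compound 3 (`CCN(C)Cc1c(OC)cc(OC)c(C(=O)/C=C/c2ccccc2Cl)c1O`) has not yet been measured.

The change from compound 2 to compound 3 is methyl in place of carboxy on a saturated chain carbon bound to an amine nitrogen. In words, this is methyl in place of carboxy on a saturated chain carbon bound to an amine nitrogen, or (carboxymethyl)(methyl)amino to ethyl(methyl)amino when cut one bond further out.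

Among the measured compounds shown here, only one measured step bears on this change: a 31-fold higher number from compound 1 to compound 2 (1.48 log units; beyond the scatter), a large step with (carboxymethyl)(methyl)amino in place of pyrrolidin-1-yl. Compound 3, like compound 1 at 2600 nM, carries no carboxy. A large step towards lower numbers in this assay is therefore expected, similar in size to that measured step, although a single pair gives thin support.

The expected change is a 23-fold lower number from compound 2 to compound 3 (1.36 log units; beyond the scatter). For compound 3, the estimated value is 3500 nM, with an expected range of 1200 nM to 12000 nM.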

Compound 3, half-maximal inhibitory concentration: 1300 nM
Compound 3: middle estimate off by 2.7-fold (0.43 log units), on the high side, and the stated range covers the measured number.
By their numbers in this assay, from the lowest: compounds 3 and 1 (each within the scatter of the next); then compound 2.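

In this assay there is a 61-fold lower number from compound 2 to compound 3 (1.79 log units; beyond the scatter), which shows that methyl in place of carboxy on a saturated chain carbon bound to an amine nitrogen is enough on its own for a large step, with the rest of the molecule unchanged. There is also a 2.0-fold lower number from compound 1 to compound 3 (0.30 log units; within the scatter), within the scatter, so ethyl(methyl)amino and pyrrolidin-1-yl cannot be told apart here, and the pyrrolidin-1-yl group is not required for numbers of this size. The large step measured earlier between the pyrrolidin-1-yl compound and the carboxy compound can now be tied to the carboxy rather than to the loss of pyrrolidin-1-yl, though nothing available explains why the carboxy has this consequence.

Still open, as far as these compounds go, is whether the step belongs to the carboxylic acid as such, which a methyl ester, a primary amide or a hydroxymethyl group at the same place would test. Also open, from the compounds shown here alone, is how far the amine tolerates change, for example a longer chain such as propyl or butyl in place of ethyl, or a morpholine in place of pyrrolidin-1-yl.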